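The source may report more compounds than this note shows. Statements on the series, on what has been measured and on what is new or still open speak of the compounds shown alone.

Compound 1 `Cn1c(/C=C/C(=O)c2ccccc2O)cc(Br)c1Br`, compound 2 `Cn1c(/C=C/C(=O)c2ccccc2)cc(Br)c1Br` and compound 3 `Cn1c(/C=C/C(=O)c2cccc(O)c2)cc(Br)c1Br` share one core and differ only in hydroxy groups on the ring attached to the carbonyl. In a functional assay on Caco-2 cells (Homo sapiens) for cytotoxicity, read by MTT assay, with stated times of 6 h and 48 h (on this read-out lower numbers stand for stronger inhibition and higher numbers for weaker inhibition), compound 1 gives 3160 nM. For compound 2 the assay reports only a limit, >= 100000 nM. For compound 3 it again reports only a limit, >= 100000 nM, so the exact standing of compound 3 is not known. Both rest on (the limit of >= 100000 nM in this assay, at which 2 of the 3 values shown sit). The step of an at least 31-fold higher number from compound 1 to compound 2 (1.50 log units; beyond the scatter) is large, whereas the next one is a step that the two limits leave unreadable from compound 2 to compound 3. Compound 4 `Cn1c(/C=C/C(=O)c2cc(O)ccc2O)cc(Br)c1Br` arises from compound 3 by hydroxy in place of hydrogen on an aromatic carbon, so compound 4 carries both hydroxy groups found in compound 1 and compound 3. Because compound 1 gives 3160 nM, compound 4 is expected to return to a readable number, a step of an at least 20-fold lower number from compound 3 to compound 4 (1.30 log units; beyond the scatter). The estimate for compound 4 is 5000 nM, within 1500 nM to 50000 nM.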

Compound 4, half-maximal inhibitory concentration: >= 100000 nM
Compound 4 gave a limit, no number; the forecaster's own chance of this, stated with the estimate: 25%; middle value at least 20-fold (1.30 log units) from the limit.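

In this assay, the hydroxy ortho to a large group does not guarantee a readable number: adding a second hydroxy to the same ring gives an at least 31-fold higher number from compound 1 to compound 4 (1.50 log units; beyond the scatter). The effect of that hydroxy therefore depends on what else the ring carries. Both results are limits, so the step from compound 3 to compound 4 cannot be read, and most of the series rests on a single limit: the limit of >= 100000 nM in this assay, at which 3 of the 4 values shown sit.

From the compounds shown here alone, how far compound 2, compound 3 and compound 4 lie beyond that limit stays open. Also open, going by these compounds, is whether an amine or a methoxy group at the position ortho to a large group would give a readable number.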